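Swapping the amine ring on the chain carbon of compound 3

The compounds below may be only part of what the source reports. "The series", "measured", "known", "first", "only" and "open" are said of these compounds alone.

Measured so far:
Compound 1, `COc1ccc2[nH]c(C(=O)N3CC(=O)N(Cc4ccccc4)[C@@H](CCc4ccccc4)C3)cc2c1`: 0.167 h
Compound 2, `COc1ccc2[nH]c(C(=O)N3CC(=O)N(Cc4ccccc4)[C@@H](N4[C@H](C)CCC[C@@H]4C)C3)cc2c1`: 0.112 h
Compound 3, `COc1ccc2[nH]c(C(=O)N3CC(=O)N(Cc4ccccc4)[C@@H](CN4CC5CCCCC5C4)C3)cc2c1`: 0.233 h

In an ADME assay on microsomes from liver (Homo sapiens) for metabolic stability, with a stated time of 30 min, tested at 1 uM (on this read-out lower numbers stand for a shorter-lived compound and higher numbers for a longer-lived compound), compound 3 gives the highest of the numbers shown. Its nearest neighbour is compound 1 (a 1.4-fold higher number from compound 1 to compound 3 (0.14 log units; within the scatter)), and its furthest is compound 2 (a 2.1-fold higher number from compound 2 to compound 3 (0.32 log units; beyond the scatter)). The remaining pair, compound 1 to compound 2, shows a 1.5-fold lower number from compound 1 to compound 2 (0.17 log units; within the scatter).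

Compound 4, `COc1ccc2[nH]c(C(=O)N3CC(=O)N(Cc4ccccc4)[C@@H](CN4CCc5ccccc5C4)C3)cc2c1`, is not yet measured in this assay. It differs from compound 3 in one place: a group of 10 heavy atoms (9 carbon, 1 nitrogen; one six-membered non-aromatic ring with 1 hetero atom, one six-membered aromatic ring of carbon only) in place of a group of 9 heavy atoms (8 carbon, 1 nitrogen; one five-membered non-aromatic ring with 1 hetero atom, one six-membered non-aromatic ring of carbon only), on a saturated chain carbon bound to a saturated ring carbon. Within the data shown here, two measured steps bear on this change, since both alter the substituent at this part of the shared core: from compound 1 to compound 3 the number stayed within the scatter, and from compound 2 to compound 3 it moved modestly. Neither step involved the 1,2,3,4-tetrahydroisoquinolin-2-yl group, so the direction for compound 4 is uncertain; a step no larger than the scatter is expected, a 1.2-fold lower number from compound 3 to compound 4 (0.07 log units; within the scatter). Compound 4 is therefore estimated at 0.2 h, with a range from 0.1 h to 0.4 h.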

Compound 4, half-life: 0.617 h
Compound 4: the middle estimate sits 3.1-fold (0.49 log units) below what was measured; the whole stated range lies below it.
By their numbers in this assay, from the lowest: compounds 2, 1 and 3 (each within the scatter of the next, the first and the last beyond it); then compound 4.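

In this assay, the 1,2,3,4-tetrahydroisoquinolin-2-yl group on the saturated chain carbon gives a step beyond the scatter, a 2.6-fold higher number from compound 3 to compound 4 (0.42 log units; beyond the scatter), so exchanging one amine ring system for another at this position can change the half-life. Compound 4 also stands clear of the other two compounds, with a 3.7-fold higher number from compound 1 to compound 4 (0.57 log units; beyond the scatter) and a 5.5-fold higher number from compound 2 to compound 4 (0.74 log units; beyond the scatter), which makes it the only one of the four whose steps to all the others lie beyond the scatter, and the longest-lived of them. No measured evidence accompanies these compounds to account for the rise.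

On these data alone, whether the aromatic ring of the entering group is what matters remains open, and a piperidin-1-yl or 4-phenylpiperidin-1-yl group on the same chain carbon would bear on that. Also open, as far as these compounds go, is whether a methoxy or fluoro group on that aromatic ring would keep the half-life of compound 4.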